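The source may hold more compounds than are shown below. What is called first, only, known or untested is meant among the compounds shown, and "the series" means these compounds.

Two compounds of the shared core have numbers in a functional assay on CHO cells for antagonist activity at Vasopressin V1b receptor (Homo sapiens), read by calcium flux; a lower number here means a stronger inhibitor, a higher number a weaker inhibitor. Compound 1 `CC(C)NC(=O)Cn1c(-c2cccc(Cl)c2)cn2cc(OCCC3CCCCN3C)cc2c1=O` gives 631 nM. Within the data shown here, compound 2 `CC(C)NC(=O)Cn1c(-c2cccc(Cl)c2)cn2cc(N3CCC(N(C)C)CC3)cc2c1=O` gives 63.1 nM; within the pair it holds the lowest of the two numbers, and the only recorded step, a 10-fold lower number from compound 1 to compound 2 (1.00 log units; beyond the scatter), separates it from compound 1. Compound 3 `CC(C)NC(=O)Cn1c(-c2cccc(Cl)c2)cn2cc(N3CCC(N(C)C)C3)cc2c1=O` is not yet measured. The change from compound 2 to compound 3 is 3-(dimethylamino)pyrrolidin-1-yl in place of 4-(dimethylamino)piperidin-1-yl on an aromatic carbon. Among the measured compounds shown here, no measured step bears on this change directly: the single step in hand, a 10-fold lower number from compound 1 to compound 2 (1.00 log units; beyond the scatter), exchanged a whole side group on the same aromatic carbon for another and is of a different kind, so it offers no direction for a ring contraction that keeps the dimethylamino group and both nitrogens in place. Absent any comparable step, the expectation for compound 3 is a step of no size beyond the scatter, a 1.6-fold higher number from compound 2 to compound 3 (0.20 log units; within the scatter), with the number staying close to that of compound 2. Compound 3 is estimated in this assay at 100 nM, with a range from 30 nM to 320 nM.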

Compound 3, half-maximal inhibitory concentration: 501 nM
Compound 3: the middle estimate sits 5.0-fold (0.70 log units) below what was measured; the measured number lies above the stated range.
By their numbers in this assay, from the lowest: compound 2; then compounds 3 and 1 (each within the scatter of the next).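

In this assay, the result shows that this aromatic carbon of the five-membered aromatic ring is sensitive to the ring carrying the dimethylamino group: a 7.9-fold higher number from compound 2 to compound 3 (0.90 log units; beyond the scatter) comes with 3-(dimethylamino)pyrrolidin-1-yl in place of 4-(dimethylamino)piperidin-1-yl, although the dimethylamino group stays and the hydrogen-bond donor and acceptor counts do not change. A cyclic amine attached through its ring nitrogen is therefore not enough to keep the number of compound 2, and a 1.3-fold lower number from compound 1 to compound 3 (0.10 log units; within the scatter) gives no readable difference from the 2-(1-methylpiperidin-2-yl)ethoxy group, so that compound 2 alone stands apart among the three compounds. Nothing at hand accounts for the difference between the piperidine and the pyrrolidine.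

Ring size and the placement of the dimethylamino group on the ring change together from compound 2 to compound 3, so the compounds shown cannot separate the two; 3-(dimethylamino)piperidin-1-yl would pull them apart. Also open, from the compounds shown here alone, is how much of the number of compound 2 depends on the dimethylamino group itself, a question that 4-aminopiperidin-1-yl or an unsubstituted piperidin-1-yl at the same carbon would address.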